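A few compounds are considered here, and "the series" means these few. Any claim that something is new, unique, unknown or untested is made for them only; others in the source may bear on it.

Compound 1 `COc1cc(C)cc(-c2c(-c3ccnc(-c4ccc(C(C)=O)cc4)c3)cnn2CC#N)c1` is one of two compounds whose growth inhibition has been measured here. In a functional assay on Malme-3M cells (Homo sapiens) for inhibition, read by sulforhodamine B assay, with a stated time of 48 h (on this read-out lower numbers stand for stronger inhibition of growth and higher numbers for weaker inhibition of growth), compound 1 gives 5820 nM, the higher of the two numbers. Compound 2 `Cc1cc(O)cc(-c2nn(CC#N)cc2-c2ccnc(-c3ccc(Oc4ccccc4)cc3)c2)c1` differs from it in more than one place; in this assay compound 2 gives 1810 nM, and the gap between these two values lies beyond the usual scatter of the measurement. Compound 3 `COc1cc(C)cc(-c2c(-c3ccnc(-c4ccc(N(C)C)cc4)c3)cnn2CC#N)c1` is the compound still to be measured. It arises from compound 1 by a single change: dimethylamino in place of acetyl on an aromatic carbon. For the measured compounds named here, no measured pair of compounds shows a change of this kind, so there is no direct guide to its effect. On the numbers available, the step expected in this assay is a 1.2-fold lower number from compound 1 to compound 3 (0.07 log units; within the scatter), in no settled direction and probably not beyond the scatter. Compound 3 is therefore expected to give about 5000 nM in this assay, with a range from 2000 nM to 12500 nM.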

Compound 3, concentration for 50% growth inhibition: 59.8 nM
The estimate for compound 3 lay 84-fold (1.92 log units) above the measured number; measured number below the stated range.
By their numbers in this assay, from the lowest: compound 3; then compound 2; then compound 1.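

In this assay the exchange of 4-acetylphenyl for 4-(dimethylamino)phenyl gives a 97-fold lower number from compound 1 to compound 3 (1.99 log units; beyond the scatter) and so shows that growth inhibition is highly sensitive to the group at this place, para to a large group on the aromatic ring of carbon only. The two groups have the same heavy-atom count, and each has one hydrogen-bond acceptor and no donor, so these counts do not separate them, even though the outcomes lie far apart. Nothing measured here gives the reason for this gain.

From the compounds shown here alone, it remains open whether the gain is specific to dimethylamino, or whether a primary amine, a pyrrolidine ring or a methoxy group at this place would match it. Going by these compounds, it is also open whether the same exchange would have a similar effect if another part of the shared core were changed.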